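Side-chain changes on a shared core: cytotoxicity notes

This account rests on a few compounds, and the source may have more. Where it says the series, first, only, none or still open, it means among the compounds named here.

compound 1 `C=C[C@@]1(C)O[C@H]1C[C@H]1C(=C)CC[C@@H]2[C@]1(C)CCC[C@]2(C)C(=O)O` — > 40000 nM
compound 2 `C=C[C@@](C)(O)CC[C@H]1C(=C)CC[C@@H]2[C@]1(C)CCC[C@]2(C)C(=O)O` — > 40000 nM

In a functional assay on MCF7 cells (Homo sapiens) for cytotoxicity, read by MTT assay, with a stated time of 48 h (on this read-out higher numbers stand for weaker inhibition and lower numbers for stronger inhibition), compound 1 gives only a limit, > 40000 nM. Compound 2 likewise gives only a limit, > 40000 nM. The step that the two limits leave unreadable from compound 1 to compound 2 is therefore unreadable in size. Compound 2 stands at the limit of > 40000 nM in this assay, at which 2 of the 2 values shown sit, with no numerical value for it or for any other compound in this assay.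

Compound 3 `C=CC(=C)[C@H](O)C[C@H]1C(=C)CC[C@@H]2[C@]1(C)CCC[C@]2(C)C(=O)O` differs from compound 2 in one place: a group of 6 heavy atoms (5 carbon, 1 oxygen; no ring) in place of a group of 6 heavy atoms (5 carbon, 1 oxygen; no ring), on a saturated chain carbon bound to a saturated ring carbon. The 2-hydroxy-2-methylbut-3-en-1-yl group leaves, carrying one double bond outside aromatic rings, and a group with two double bonds outside aromatic rings enters, each with one hydrogen-bond donor and one hydrogen-bond acceptor.

Going by the values given here, the only measured step, from compound 1 to compound 2, is unreadable, so it gives no size to carry over. Compound 3 is expected to give 40000 nM, within 10000 nM to 160000 nM. The step of a number no higher from compound 2 to compound 3 (the limit leaves the size open) is expected to stay within the scatter.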

Compound 3, half-maximal inhibitory concentration: > 40000 nM
Compound 3: only a limit was reported (the forecaster's own chance of this, stated with the estimate: 70%); the middle value sits exactly at the limit.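

Compound 3 gives only a limit in this assay, > 40000 nM. Going by these compounds alone, no step among compound 1, compound 2 and compound 3 can be read. The compounds shown leave open whether any of these side chains alters cytotoxicity, as all values remain at the limit: the limit of > 40000 nM in this assay, at which 3 of the 3 values shown sit.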